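The source may report more compounds than this note shows. Statements on the series, on what has been measured and on what is new or still open speak of the compounds shown alone.

Compound 1 `O=C(Nc1cccc(C(=O)O/N=C2\CCCc3noc(-c4ccc(F)cc4)c32)c1)c1cccc(F)c1` gives > 25000 nM in a functional assay on HCC1954 cells (Homo sapiens) for antiproliferative activity, read by MTT assay, with a stated time of 72 h (a higher number here means a weaker inhibitor, a lower number a stronger inhibitor), which is a limit of the assay and not a number.
Compound 2 `O=C(Nc1cccc(C(=O)O/N=C2\CCCc3noc(-c4cccc(F)c4)c32)c1)c1cccc(F)c1` gives > 25000 nM in this assay, again a limit and not a number.

Going by the values given here, compound 1 therefore stands only at a limit in this assay, and the one other value shown is a limit as well. Among the compounds with values here, the single measured step, a step that the two limits leave unreadable from compound 1 to compound 2, cannot be read, since both ends sit at the limit of > 25000 nM in this assay, at which 2 of the 2 values shown sit. Compound 3 `Nc1cccc(C(=O)Nc2cccc(C(=O)O/N=C3\CCCc4noc(-c5ccc(F)cc5)c43)c2)c1` differs from compound 1 in that (amino in place of fluoro on an aromatic carbon). Within the data shown here, no measured step touches this position, and the step from compound 1 to compound 2 gives no readable size to lean on. With nothing to suggest a gain, the step from compound 1 to compound 3 is expected to be an at least 1.2-fold lower number from compound 1 to compound 3 (0.09 log units; that floor lies within the scatter), which is to say no movement beyond the scatter that can be read off a limit. Compound 3 is therefore estimated at 20000 nM in this assay, within a range from 4000 nM to 60000 nM, with a real chance that only a limit is reported.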

Compound 3, half-maximal inhibitory concentration: > 25000 nM
Compound 3 gave a limit, no number; the forecaster's own chance of this, stated with the estimate: 60%; middle value at least 1.2-fold (0.09 log units) from the limit.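

No new step can be read: compound 3, like compound 1, stands only at a limit in this assay, so the step between them has no readable size, and all the values shown sit at that same limit: the limit of > 25000 nM in this assay, at which 3 of the 3 values shown sit. The compounds shown leave open which change, if any, to the shared core would give a measurable number in this assay.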